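The source may hold more compounds than are shown below. What is called first, only, known or untested is meant among the compounds shown, and "the series" means these compounds.

Measured compounds:
compound 1, `O=C1N/C(=N/c2ccccc2)S/C1=C\c1ccccn1`: 26.2%
compound 2, `O=C1N/C(=N/c2ccc(F)cc2)S/C1=C\c1ccccn1`: 34.7%

In a functional assay on the whole organism (strain Wistar) for inhibition, with Rattus norvegicus as the target, read by paw edema, with stated times of 30 min and 120 min, at a dose of 10 mg/kg by the oral route (a lower number here means less inhibition, a higher number more inhibition at the dose given (going by the name of the read-out)), compound 1 gives 26.2%, the lowest of the two numbers recorded, while compound 2 gives 34.7%. The step of a number 8.5 percentage points higher from compound 1 to compound 2 (within the scatter) is within the scatter, so the two cannot be ordered. Compound 3, `O=C1N/C(=N/c2cccc([N+](=O)[O-])c2)S/C1=C\c1ccccn1`, differs from compound 1 by nitro in place of hydrogen on an aromatic carbon. Going by the values given here, the only measured step that bears on this change is the one that likewise swaps out a ring hydrogen of the same six-membered ring, there for fluoro; that step, a number 8.5 percentage points higher from compound 1 to compound 2 (within the scatter), stayed within the scatter. On this single precedent no step beyond the scatter is expected in this assay from compound 1 to compound 3, with at most a slight upward lean. Compound 3 is therefore estimated at 32%, with a range of 18% to 46%, an expected step of a number 5.8 percentage points higher from compound 1 to compound 3 (within the scatter).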

Compound 3, a percentage reported as inhibition, in the whole organism at one dose (the size of the read-out at that dose, not a potency): 43.5%
The estimate for compound 3 lay 11.5 percentage points below the measured number, and the stated range covers the measured number.
By their numbers in this assay, from the lowest: compounds 1, 2 and 3 (each within the scatter of the next, the first and the last beyond it).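

In this assay, going by these compounds alone, nitro in place of hydrogen on an aromatic carbon, meta to a large group, gives a number 17.3 percentage points higher from compound 1 to compound 3 (beyond the scatter), the first step that lies beyond the scatter. It shows that this place on the six-membered aromatic ring of carbon only accepts a group of 3 heavy atoms without loss of inhibition at the dose given, and that a single change there can move the read-out measurably above that of compound 1. No measurement at hand accounts for the size of this step.

The compounds shown leave open whether nitro elsewhere on the ring would give a similar step. They also leave open whether an amine or a carboxylic acid at this same place would match, exceed or fall short of it.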